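Amide head swap from compound 2 to compound 3

The source may hold more compounds than are shown below. What is called first, only, known or untested is meant among the compounds shown, and "the series" means these compounds.

Measured so far:
compound 1 `COc1cc(NC(=O)c2ncccn2)c2ncccc2c1` — 9000 nM
compound 2 `Cc1cnc(C(=O)Nc2cc(OCCC3CCNCC3)cc3cccnc23)cn1` — > 10000 nM

In a functional assay on PANC-1 cells (Homo sapiens) for inhibition, read by MTT assay, with a stated time of 72 h (a higher number here means a weaker inhibitor, a lower number a stronger inhibitor), compound 1 gives 9000 nM. For compound 2 this assay reports only a limit, > 10000 nM, so its true value is not known; it sits at the limit of > 10000 nM in this assay, at which 1 of the 2 values shown sits. Compound 3 `O=C(Nc1cc(OCCC2CCNCC2)cc2cccnc12)c1ncccn1` is the next member to be tested. It differs from compound 2 in one place: pyrimidin-2-yl in place of 5-methylpyrazin-2-yl on a carbonyl carbon. Among the compounds with values here, no step between measured compounds is on record for this change, so its size cannot be read off. Compound 1 carries the same pyrimidin-2-yl carbonyl group and gives a value near the limit seen for compound 2, which gives no ground to expect a step beyond the usual scatter in either direction. Compound 3 is therefore expected to land at 10000 nM, with a range of 3000 nM to 30000 nM; the step of a number no higher from compound 2 to compound 3 (the limit leaves the size open) is an estimate only, and a further limit-only reading is about as likely as a number.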

Compound 3, half-maximal inhibitory concentration: > 10000 nM
Compound 3 was reported as a limit (the forecaster's own chance of this, stated with the estimate: 55%); the middle value sits exactly at the limit.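

In this assay compound 3 gives > 10000 nM and this is a limit, not a number. The step for the swap on the carbonyl carbon cannot be read, and neither 5-methylpyrazin-2-yl nor pyrimidin-2-yl gives a number on the side-chain compounds: the limit of > 10000 nM in this assay, at which 2 of the 3 values shown sit.
With pyrimidin-2-yl held constant, (piperidin-4-yl)methyl in place of hydrogen on the saturated chain carbon gives an at least 1.1-fold higher number from compound 1 to compound 3 (0.04 log units; that floor lies within the scatter) and so shows no gain in this assay from this side chain.

From the compounds shown here alone, the true size of that step remains open, as do the true values behind both limits. Also open, going by these compounds, is whether a carboxylic acid or a dimethylamino group on the head ring, or a longer chain in place of the side chain, would give a number rather than a limit.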